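Swapping the aryl ring on compound 1's saturated core

This account rests on a few compounds, and the source may have more. Where it says the series, first, only, none or still open, it means among the compounds named here.

Compound 1, `COc1cc(C2=NN(C(C)=O)C(c3cc(Cl)cc(Cl)c3)O2)cc(OC)c1OC`, gives 93.9%.
Compound 2, `COc1ccc(OC)c(/C=N/NC(=O)c2cc(OC)c(OC)c(OC)c2)c1`, gives 51.7%.
Compound 3, `COc1cc(C(=O)N/N=C/c2ccc(F)cc2)cc(OC)c1OC`, gives 82.8%.

These three numbers come from a functional assay on PC-3 cells (Homo sapiens) for antiproliferative activity, read by MTT assay, tested at 5 uM; a lower number here means a weaker effect, a higher number a stronger effect of the compound at the concentration tested. Compound 1 stands highest of the three. Its nearest neighbour is compound 3, whose number is lower by a gap beyond the usual scatter; the furthest is compound 2, whose number is lower by a much wider gap, also beyond the scatter. Compound 1 is therefore the strongest of the three in this assay.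

Compound 4, `COc1cc(C2=NN(C(C)=O)C(c3ccc(Cl)c([N+](=O)[O-])c3)O2)cc(OC)c1OC`, has not yet been measured in this assay. It differs from compound 1 in one place: 4-chloro-3-nitrophenyl in place of 3,5-dichlorophenyl on a saturated ring carbon. The change sits on the saturated ring carbon of the five-membered non-aromatic ring, next to the ring nitrogen and the ring oxygen, and the aromatic ring itself stays a six-membered ring of carbon only.

Among the compounds with values here, no pair among the measured compounds shows the effect of such a swap, so the expectation rests only on where compound 1 stands. Compound 4 is expected to give 85%, somewhere between 60% and 97%. That estimate means an expected step of a number 8.9 percentage points lower from compound 1 to compound 4 (within the scatter), small, downward if anything, and possibly within the scatter.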

Compound 4, a percentage reported as inhibition, at one concentration (the size of the read-out at that concentration, not a potency): 61.4%
Estimate against measurement, compound 4: 23.6 percentage points above; low and high end bracket the measured number.
By their numbers in this assay, from the lowest: compounds 2 and 4 (each within the scatter of the next); then compound 3; then compound 1.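

In this assay, replacing 3,5-dichlorophenyl with 4-chloro-3-nitrophenyl on the saturated ring carbon gives a step of a number 32.5 percentage points lower from compound 1 to compound 4 (beyond the scatter). Within the data shown here, this is the first pair here that differs in only one place, and it shows that this position of the shared core is sensitive to what the aromatic ring carries, even though the ring itself stays a six-membered ring of carbon only. The swap alters more than one feature at once: one chlorine gives way to a nitro group, the group has more heavy atoms, and its hydrogen-bond acceptors go from 0 to 2, but nothing available explains which of these matters or why the number falls.

The compounds shown leave open whether the fall follows the arrival of the nitro group or the loss of the 3,5-dichloro arrangement. A phenyl ring carrying an amine or a nitrile in place of the nitro group, with the chlorine kept, would help separate those two readings, and so would a 3,5-dibromophenyl ring on the same carbon.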